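A few compounds are considered here, and "the series" means these few. Any claim that something is new, unique, unknown or untested is made for them only; others in the source may bear on it.

Measured in a functional assay on BXPC-3 cells (Homo sapiens) for antiproliferative activity, read by MTT assay, with a stated time of 24 h; a lower number here means a stronger inhibitor, a higher number a weaker inhibitor:

Compound 1 `CCn1c(C(=O)NC2(CO)CC2)ccc1C(CC)(CC)c1ccc(OCS(=O)(=O)c2ccccc2)c(C)c1` gives 45400 nM
Compound 2 `CCn1c(C(=O)NCC(=O)O)ccc1C(CC)(CC)c1ccc(OCS(=O)(=O)c2ccccc2)c(C)c1` gives > 50000 nM (a limit)
Compound 3 `CCn1c(C(=O)N[C@H](C(=O)O)C(C)C)ccc1C(CC)(CC)c1ccc(OCS(=O)(=O)c2ccccc2)c(C)c1` gives 16200 nM

Compound 3 has the lowest of the two actual numbers in this assay, with compound 1 nearest to it. Compound 2 reports only a limit, not a number, and sits at > 50000 nM. Two measured steps reach compound 3, both through the group on the amide-type nitrogen. One is a 2.8-fold lower number from compound 1 to compound 3 (0.45 log units; beyond the scatter). The other, isopropyl in place of hydrogen on a saturated chain carbon, is an at least 3.0-fold lower number from compound 2 to compound 3 (0.48 log units; beyond the scatter).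

Compound 4 `CCn1c(C(=O)N[C@@H](C(=O)O)C(C)C)ccc1C(CC)(CC)c1ccc(OCS(=O)(=O)c2ccccc2)c(C)c1` departs from compound 3 in one way only: the two compounds have the same atoms and bonds and differ only in configuration as drawn: 1 of 1 stereo elements differ; a stereocentre at a saturated chain carbon is drawn S in compound 3 and R in compound 4. A stereocentre at a saturated chain carbon is drawn S in compound 3 and R in compound 4. Among the compounds with values here, no measured step tests a change of configuration, so the evidence is indirect. Within the data shown here, the steps above show only that changes to this group have moved the number modestly, and they give no direction for this inversion. A step of similar or smaller size is therefore expected, leaning slightly towards a higher number, as compound 3 has the lowest value of the series. The expected change is a 1.4-fold higher number from compound 3 to compound 4 (0.13 log units; within the scatter). The estimated value for compound 4 is 22000 nM, with an expected range from 9000 nM to 50000 nM.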

Compound 4, half-maximal inhibitory concentration: 13900 nM
Compound 4: the middle estimate sits 1.6-fold (0.20 log units) above what was measured, within the range that was stated.
By their numbers in this assay, from the lowest: compounds 4 and 3 (each within the scatter of the next); then compound 1. At a limit, above all of these: compound 2.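

Inverting the stereocentre on the saturated chain carbon bound to an amide-type nitrogen and a carbonyl carbon, drawn S in compound 3 and R in compound 4, gives in this assay a 1.2-fold lower number from compound 3 to compound 4 (0.07 log units; within the scatter) and so does not separate the two drawn configurations of the 1-carboxy-2-methylpropyl group. The lower number seen with that group therefore holds for both configurations: with the R form, the replacement of 1-(hydroxymethyl)cyclopropyl gives a 3.3-fold lower number from compound 1 to compound 4 (0.51 log units; beyond the scatter) and stays beyond the scatter, as it did with the S form. Isopropyl in place of hydrogen likewise stays beyond the scatter in the R form, with an at least 3.5-fold lower number from compound 2 to compound 4 (0.55 log units; beyond the scatter) as a floor and not an exact size, as compound 2 reports only a limit: the limit of > 50000 nM in this assay, at which 1 of the 4 values shown sits.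

The compounds shown leave open whether a longer chain or a benzyl group on this carbon, in place of isopropyl, would move the number further. They also leave open whether a methyl ester or a primary amide in place of the carboxylic acid would keep the number of compound 3 and compound 4.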